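A few compounds are considered here, and "the series" means these few. Any claim that something is new, unique, unknown or untested is made for them only; others in the source may bear on it.

Measured compounds:

compound 1 `COc1cc(-c2nn(-c3ccc(NC(=O)Nc4ccc(Cl)c(Cl)c4)cc3)cc2-c2ccncc2)ccc1Cl`: 3170 nM
compound 2 `COc1cc(-c2nn(-c3ccc(NC(=O)Nc4cc(C(F)(F)F)cc(C(F)(F)F)c4)cc3)cc2-c2ccncc2)ccc1Cl`: 2300 nM

Both compounds share one core and differ only in the substituted aromatic ring at the far end of the urea. In a functional assay on UACC-257 cells (Homo sapiens) for antiproliferative activity, read by sulforhodamine B assay, with a stated time of 48 h (on this read-out higher numbers stand for weaker inhibition and lower numbers for stronger inhibition), compound 1 gives 3170 nM, the higher of the two numbers, and compound 2 gives 2300 nM; the gap between them lies within the scatter, so the two compounds cannot be told apart on this read-out.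

Compound 3 `COc1cc(-c2nn(-c3ccc(NC(=O)c4cc(Cl)cc(Cl)c4)cc3)cc2-c2ccncc2)ccc1Cl` has not yet been tested. It keeps the whole core of compound 1 and changes a single spot: 3,5-dichlorophenyl in place of (3,4-dichlorophenyl)amino on a carbonyl carbon. Put differently, the urea link of compound 1 becomes an amide link in compound 3, and the two chlorines on the outer ring take up a different arrangement.

Among the measured compounds shown here, no pair of measured compounds shows this change, so its effect can only be guessed. The step from compound 1 to compound 3 is expected to be a 1.4-fold higher number from compound 1 to compound 3 (0.15 log units; within the scatter), tending toward a somewhat weaker inhibition, but possibly no more than the scatter. Compound 3 is therefore estimated at 4500 nM, with a plausible range from 1500 nM to 14000 nM.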

Compound 3, half-maximal inhibitory concentration: > 100000 nM
Compound 3 ended at the assay's limit; the forecaster's own chance of this, stated with the estimate: 15%; middle value at least 22-fold (1.34 log units) from the limit.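

The earlier compounds shown here, compound 1 and compound 2, both keep the urea link and differ only in the outer ring, and their numbers cannot be told apart. Among the compounds shown here, compound 3 is the first to change the link itself, and in this assay this gives an at least 31-fold higher number from compound 1 to compound 3 (1.49 log units; beyond the scatter), so this end of the molecule is far from indifferent to change once the urea is altered. For compound 3 the value > 100000 nM is a limit of the assay and not a number: the limit of > 100000 nM in this assay, at which 1 of the 3 values shown sits.

The step joins two changes in one, since the amino nitrogen with its hydrogen-bond donor leaves and the chlorines take up a new arrangement, and the compounds shown cannot say which of the two carries the effect; a urea bearing 3,5-dichlorophenyl or an amide bearing 3,4-dichlorophenyl would separate them. Also open, on these data alone, is how other links on the same carbonyl carbon would read in this assay, such as a carbamate with an oxygen in place of the amino nitrogen, or a methylene at that spot.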